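Swapping the Aryl Group on Compound 3

The compounds below may be only part of what the source reports. "The series", "measured", "known", "first", "only" and "open" are said of these compounds alone.

Measured compounds:
compound 1 `COc1cc2c(Oc3ccc(NC(=O)c4nn(-c5ccccc5C)cc(C)c4=O)cc3)ccnc2cc1OCCCCCC(=O)NO` — 1830 nM
compound 2 `COc1cc2c(Oc3ccc(NC(=O)c4nn(-c5ccc(C)cc5C)cc(C)c4=O)cc3)ccnc2cc1OCCCCCCC(=O)NO` — 2430 nM
compound 3 `COc1cc2c(Oc3ccc(NC(=O)c4nn(-c5cccc(C(F)(F)F)c5)cc(C)c4=O)cc3)ccnc2cc1OCCCCCCC(=O)NO` — 750 nM

In a functional assay on MCF7 cells (Homo sapiens) for inhibition, read by MTT assay, with a stated time of 72 h (a lower number here means a stronger inhibitor, a higher number a weaker inhibitor), compound 3 gives 750 nM, the lowest of the three values; compound 1 and compound 2 both stand above it. Compound 4 `COc1cc2c(Oc3ccc(NC(=O)c4nn(-c5ccccc5C)cc(C)c4=O)cc3)ccnc2cc1OCCCCCCC(=O)NO` has not been measured. It differs from compound 3 by 2-methylphenyl in place of 3-(trifluoromethyl)phenyl on an aromatic nitrogen. For the measured compounds named here, the one measured step at this position is a 3.2-fold lower number from compound 2 to compound 3 (0.51 log units; beyond the scatter), where a methyl-bearing phenyl ring gave way to the 3-(trifluoromethyl)phenyl ring; the change to compound 4 runs the other way, so a modest rise in the number is expected. Compound 1 carries the same 2-methylphenyl group on a shorter chain and shows 1830 nM, which points the same way. Compound 4 is therefore expected to give 2000 nM, with a range of 900 nM to 4500 nM. The expected step is a 2.7-fold higher number from compound 3 to compound 4 (0.43 log units; beyond the scatter).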

Compound 4, half-maximal inhibitory concentration: 1830 nM
Beside the measured number, compound 4's estimate is 1.1-fold (0.04 log units) above it; measured number inside the range.
By their numbers in this assay, from the lowest: compound 3; then compounds 1, 4 and 2 (each within the scatter of the next).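

In this assay, the two aryl groups can now be compared on the same chain, and 2-methylphenyl in place of 3-(trifluoromethyl)phenyl gives a 2.4-fold higher number from compound 3 to compound 4 (0.39 log units; beyond the scatter) at this position. Hydrogen in place of the extra ring methyl gives a 1.3-fold lower number from compound 2 to compound 4 (0.12 log units; within the scatter) and so has no readable effect here. The chain difference gives no change at the digits printed from compound 1 to compound 4 (within the scatter) and likewise has no readable effect, so the aryl swap alone stands beyond the scatter.

Nothing available explains this step. From the compounds shown here alone, whether a methoxy group or chlorine on the phenyl ring, or a longer chain, would shift the number remains open.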